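Hydroxy to methoxy within the chlorophenyl urea series

The source may report more compounds than this note shows. Statements on the series, on what has been measured and on what is new or still open speak of the compounds shown alone.

Of the compounds shown here, three built on one shared core have been read in a functional assay on A549 cells (Homo sapiens) for inhibition, read by sulforhodamine B assay, with a stated time of 48 h, tested at 100 uM; on this read-out higher numbers stand for a weaker effect at the one concentration tested and lower numbers for a stronger effect. Compound 1 `O=C(Nc1cccc(-n2cc(-c3ccncc3)c(-c3cc(O)cc(Cl)c3)n2)c1)Nc1ccc(Cl)c(Cl)c1` gives -32% in this assay, the highest of the three numbers. Compound 2 `COc1cc(Cl)cc(-c2nn(-c3cccc(NC(=O)Nc4ccc(Cl)c(C(F)(F)F)c4)c3)cc2-c2ccncc2)c1` gives -76% and compound 3 `COc1cc(Cl)cc(-c2nn(-c3cccc(NC(=O)Nc4cc(C(F)(F)F)cc(C(F)(F)F)c4)c3)cc2-c2ccncc2)c1` gives -68%, each beyond the scatter below compound 1. For the measured compounds named here, both carry methoxy where compound 1 carries hydroxy, yet they also differ from compound 1 elsewhere, so no measured pair isolates that one change. Compound 4 `COc1cc(Cl)cc(-c2nn(-c3cccc(NC(=O)Nc4ccc(Cl)c(Cl)c4)c3)cc2-c2ccncc2)c1` differs from compound 1 in a single place: methyl in place of hydrogen on an oxygen on an aromatic ring. Going by the values given here, with no measured step for this change, the expected move is a number 23 percentage points lower from compound 1 to compound 4 (beyond the scatter), downward in this assay and toward the numbers of compound 2 and compound 3, with wide uncertainty. Compound 4 is estimated at -55%, within -85% to -20%.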

Compound 4, a percentage reported as activity, at one concentration (the size of the read-out at that concentration, not a potency): -10%
The estimate for compound 4 lay 45 percentage points below the measured number; the whole stated range lies below it.
By their numbers in this assay, from the lowest: compounds 2 and 3 (each within the scatter of the next); then compound 1; then compound 4.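

In this assay, the hydroxy to methoxy change on the 3-chloro-5-hydroxyphenyl group gives a number 22 percentage points higher from compound 1 to compound 4 (beyond the scatter), so methoxy at this oxygen does not by itself bring the stronger effect seen in compound 2 and compound 3. Chloro in place of trifluoromethyl on an aromatic carbon gives a number 66 percentage points higher from compound 2 to compound 4 (beyond the scatter), a large step against the modest one at the oxygen. Nothing shown explains either step. Open, going by these compounds, is whether trifluoromethyl in place of chloro gives a similar step with hydroxy retained. Also open, on these data alone, is how an ethoxy group or an amine would read at this place.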